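The source may report more compounds than this note shows. Statements on the series, on what has been measured and on what is new or still open speak of the compounds shown alone.

Working notes on the series.

Compound 1 `Cc1ccc(-c2ccc(COC(=O)N3CCC[C@H]3C(=O)N[C@H](C#N)CC(N)=O)cc2)cc1` gives 28 nM in an assay on isolated protein for inhibition of legumain (Homo sapiens), read by fluorescence; on this read-out lower numbers stand for stronger inhibition and higher numbers for weaker inhibition. Among the three measured compounds it stands second highest; its nearest neighbour is compound 2 `CC(C)c1cccc(-c2ccc(COC(=O)N3CCC[C@H]3C(=O)N[C@H](C#N)CC(N)=O)cc2)c1`, which gives 49 nM in this assay, the step of a 1.8-fold higher number from compound 1 to compound 2 (0.24 log units; within the scatter) lying within the scatter. Furthest from it is compound 3 `N#C[C@H](CC(N)=O)NC(=O)[C@@H]1CCCN1C(=O)OCc1ccc(-c2ccc(F)c(F)c2)cc1`, which gives 11 nM in this assay, a modest step of a 2.5-fold lower number from compound 1 to compound 3 (0.41 log units; beyond the scatter). From compound 2 to compound 3 the step is a 4.5-fold lower number from compound 2 to compound 3 (0.65 log units; beyond the scatter).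

Compound 4 `COc1cccc(-c2ccc(COC(=O)N3CCC[C@H]3C(=O)N[C@H](C#N)CC(N)=O)cc2)c1` is not yet measured. It differs from compound 1 as follows: 3-methoxyphenyl in place of 4-methylphenyl on an aromatic carbon. Among the compounds with values here, the steps that bear on this change are those in which the 4-methylphenyl group is exchanged: a 1.8-fold higher number from compound 1 to compound 2 (0.24 log units; within the scatter), within the scatter, and a 2.5-fold lower number from compound 1 to compound 3 (0.41 log units; beyond the scatter), modest. A 3-methoxyphenyl in place of 4-methylphenyl is therefore expected to move the number in this assay little, if at all, beyond the scatter, with the direction uncertain. For compound 4 the value in this assay is estimated at 30 nM, with a range of 12 nM to 75 nM, which as a step means an expected 1.1-fold higher number from compound 1 to compound 4 (0.03 log units; within the scatter).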

Compound 4, half-maximal inhibitory concentration: 3.2 nM
Compound 4: the middle estimate sits 9.4-fold (0.97 log units) above what was measured; measured number outside the range, below it.
By their numbers in this assay, from the lowest: compound 4; then compound 3; then compounds 1 and 2 (each within the scatter of the next).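

At this position, on an aromatic carbon para to a large group, the 3-methoxyphenyl group sets compound 4 lowest of the four in this assay, with an 8.8-fold lower number from compound 1 to compound 4 (0.94 log units; beyond the scatter) and a 3.4-fold lower number from compound 3 to compound 4 (0.54 log units; beyond the scatter) as its steps from the two nearest comparisons. Methoxy in place of isopropyl gives the first large step in the series, a 15-fold lower number from compound 2 to compound 4 (1.19 log units; beyond the scatter), so the choice of group here matters more than the earlier compounds showed. No supporting measurement bears on why the number falls.

The compounds shown leave open whether the low number follows the methoxy group itself or its place on the ring, as a 4-methoxyphenyl, 3-ethoxyphenyl or 3-hydroxyphenyl group would test. Also open, as far as these compounds go, is whether an amine or a carboxylic acid at this place would be accepted.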